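Half-life step from isopropyl to phenyl

A few compounds are considered here, and "the series" means these few. Any claim that something is new, unique, unknown or untested is made for them only; others in the source may bear on it.

Measured in an ADME assay on brain (Sus scrofa) for metabolic stability, read by LC-MS, with a stated time of 60 min, tested at 10 uM (on this read-out higher numbers stand for a longer-lived compound and lower numbers for a shorter-lived compound), so far:
compound 1 `CC(C)OC(=O)[C@H](CCC(=O)C=[N+]=[N-])NC(=O)O[C@H](C)OC(=O)C(C)(C)C` gives 1.25 h 
compound 2 `CC(C)OC(=O)[C@H](CCC(=O)C=[N+]=[N-])NC(=O)OC(OC(=O)C(C)(C)C)C(C)C` gives 0.583 h 

Compound 2 holds the lower of the two numbers, and its gap to compound 1 lies beyond the scatter. Compound 3 `CC(C)OC(=O)[C@H](CCC(=O)C=[N+]=[N-])NC(=O)OC(OC(=O)C(C)(C)C)c1ccccc1` differs from compound 2 by one change phenyl in place of isopropyl on a saturated chain carbon bound to two oxygens next to a carbonyl group with phenyl in place of isopropyl on a saturated chain carbon bound to two oxygens next to a carbonyl group. Among the compounds with values here, no measured step covers this change, so compound 2 at 0.583 h serves as the anchor. No step beyond the scatter is expected in this assay and a 1.2-fold lower number from compound 2 to compound 3 (0.07 log units; within the scatter) is the estimated step, slightly downward. Compound 3 is estimated at 0.5 h (expected range 0.2 h to 1.2 h).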

Compound 3, half-life: 0.517 h
Estimate against measurement, compound 3: 1.0-fold (0.01 log units) below; the range from low to high includes it.
By their numbers in this assay, from the lowest: compounds 3 and 2 (each within the scatter of the next); then compound 1.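

In this assay phenyl in place of isopropyl on a saturated chain carbon bound to two oxygens next to a carbonyl group gives a 1.1-fold lower number from compound 2 to compound 3 (0.05 log units; within the scatter) and so leaves the half-life unresolved from that of the isopropyl compound. This position therefore accepts a six-membered aromatic ring in place of a branched alkyl group with no step beyond the scatter. No supporting measurement bears on this result.

From the compounds shown here alone, whether an amine, a carboxylic acid or a longer chain at this carbon would also leave the half-life within the scatter remains open.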